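This account rests on a few compounds, and the source may have more. Where it says the series, first, only, none or still open, it means among the compounds named here.

Measured compounds in this series:

compound 1, `O=C(NC[C@@H](O)C(=O)O)c1ccc(CN(C(=O)Nc2cccc(Br)c2)c2ccc(C3CCCCC3)cc2)cc1`; in an in vitro assay on BHK cells for binding affinity to Glucagon receptor (Homo sapiens) (a higher number here means a weaker inhibitor, a lower number a stronger inhibitor), compound 1 gives 8 nM
compound 2, `COc1cc(NC(=O)N(Cc2ccc(C(=O)NC[C@@H](O)C(=O)O)cc2)c2ccc(C3=CCCCC3)cc2)cc(C(F)(F)F)c1`; compound 2 gives 14 nM
compound 3, `CC(C)(C)c1cccc(NC(=O)N(Cc2ccc(C(=O)NC[C@@H](O)C(=O)O)cc2)c2ccc(C3CCCCC3)cc2)c1`; compound 3 gives 18 nM

Compound 3 has the highest of the three numbers. Compound 2 sits closest, within the scatter of compound 3, so no order between the two can be claimed. For the measured compounds named here, compound 1 is further off, and the one step that connects it to compound 3 is a 2.3-fold higher number from compound 1 to compound 3 (0.35 log units; beyond the scatter), a modest but real move to a weaker number when the aromatic halogen is replaced.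

The next compound, compound 4, `O=C(NC[C@@H](O)C(=O)O)c1ccc(CN(C(=O)Nc2cc(Cl)cc(Cl)c2)c2ccc(C3CCCCC3)cc2)cc1`, carries 3,5-dichlorophenyl in place of 3-(tert-butyl)phenyl on an amide-type nitrogen. Going by the values given here, this reverses the direction of the only measured step that bears on it: the tert-butyl group, which in the step from compound 1 to compound 3 brought the higher number, leaves, and halogens on that ring return, now two chlorines instead of one bromine. Compound 2, with two substituents on the same ring, sits within the scatter of compound 3 and gives no further guidance. On that basis compound 4 is expected to move back toward the number of compound 1, a step of about a 2.3-fold lower number from compound 3 to compound 4 (0.35 log units; beyond the scatter) in this assay, down to an estimated 8 nM with a range of 3 nM to 25 nM.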

Compound 4, half-maximal inhibitory concentration: 4 nM
Compound 4: middle estimate off by 2.0-fold (0.30 log units), on the high side, and the stated range covers the measured number.
By their numbers in this assay, from the lowest: compounds 4, 1, 2 and 3 (each within the scatter of the next, the first and the last beyond it).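

In this assay, on the amide-type nitrogen, 3,5-dichlorophenyl in place of 3-(tert-butyl)phenyl gives a 4.5-fold lower number from compound 3 to compound 4 (0.65 log units; beyond the scatter) and is a second step beyond the scatter at this position, so both halogen-bearing rings now stand on the lower side of the tert-butyl ring. The comparison of the two halogen patterns gives a 2.0-fold lower number from compound 1 to compound 4 (0.30 log units; within the scatter) and allows no order between 3-bromophenyl and 3,5-dichlorophenyl, which shows that this position accommodates a second halogen on the ring with no change that can be read. Nothing at hand accounts for the separation between the halogen-bearing rings and the tert-butyl ring.

Open, going by these compounds, is whether halogen itself matters here or only the absence of tert-butyl, a question that a plain phenyl ring or a single chlorine on the ring would address. Also open, on these data alone, is how this position responds to a hydroxyl, an amine or a nitrile on the ring, and whether the halogen preference holds on the core of compound 2.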